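A benzoxazolone ether: from ethoxy to pyrimidinyl-ethoxy

A few compounds are considered here, and "the series" means these few. Any claim that something is new, unique, unknown or untested is made for them only; others in the source may bear on it.

Two compounds share a core and differ only in the group on the ether oxygen. Compound 1 `O=C(O)CCn1c(=O)oc2cc(OCC3CC3)c(Cl)cc21` carries a cyclopropylmethoxy group; in an assay for inhibition of kynurenine 3-monooxygenase (Homo sapiens), read by mass spectrometry, with a stated time of 1 h (a higher number here means a weaker inhibitor, a lower number a stronger inhibitor), compound 1 gives 10 nM. Compound 2 `CCOc1cc2oc(=O)n(CCC(=O)O)c2cc1Cl` carries an ethoxy group instead, and in this assay compound 2 gives 5.01 nM. Among the compounds with values here, compound 2 thus holds the lower of the two numbers, but the one step measured, a 2.0-fold lower number from compound 1 to compound 2 (0.30 log units; within the scatter), stays within the scatter, so the two are not separated.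

Compound 3 `C[C@@H](Oc1cc2oc(=O)n(CCC(=O)O)c2cc1Cl)c1ncccn1` is not yet measured. It differs from compound 2 by pyrimidin-2-yl in place of hydrogen on a saturated chain carbon bound to an oxygen on an aromatic ring and a saturated chain carbon. Within the data shown here, the only step that bears on this change is the one at the same place, a 2.0-fold lower number from compound 1 to compound 2 (0.30 log units; within the scatter), which was small. That step swapped one saturated group for another, whereas compound 3 introduces a ring with two acceptors, so the earlier step is an imperfect guide. Because the known step of a 2.0-fold lower number from compound 1 to compound 2 (0.30 log units; within the scatter) lies within the scatter, no change beyond the scatter is expected from compound 2 to compound 3, and the expected step is a 1.0-fold lower number from compound 2 to compound 3 (0.00 log units; within the scatter). For compound 3 the estimate in this assay is 5 nM, within a range from 1.5 nM to 20 nM.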

Compound 3, half-maximal inhibitory concentration: 5.01 nM
Compound 3: the middle estimate sits 1.0-fold (0.00 log units) below what was measured, within the range that was stated.
By their numbers in this assay, from the lowest: compounds 2, 3 and 1 (each within the scatter of the next).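

Putting pyrimidin-2-yl in place of hydrogen on this saturated chain carbon leaves the read-out in this assay with no change at the digits printed from compound 2 to compound 3 (within the scatter), so this position takes an aromatic ring of six atoms, with two hetero atoms, without a step beyond the scatter. The earlier compounds had shown only an exchange between saturated groups; the wider exchange of the whole group on the oxygen, with eight heavy atoms entering where four leave, gives a 2.0-fold lower number from compound 1 to compound 3 (0.30 log units; within the scatter) and likewise stays within the scatter, so all three compounds remain unseparated in this assay. Nothing among the data given explains why the added ring leaves the number where it is, and no measurement beyond this read-out bears on the result.

Going by these compounds, whether this holds for other rings or groups at the same carbon stays open, for instance phenyl, pyridin-2-yl or a dimethylamino group, as a single ring cannot show what the hetero atoms contribute. Also open, on these data alone, is how the mirror-image form at this carbon would read, since compound 3 represents one configuration only.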